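The source may report more compounds than this note shows. Statements on the series, on what has been measured and on what is new or still open speak of the compounds shown alone.

compound 1 `O=C1CC(c2ccc(Cl)c(Cl)c2)Oc2cc(O)cc(O)c21` - 63000 nM
compound 2 `O=C1CC(c2cc(F)c(F)c(F)c2)Oc2cc(O)cc(O)c21` - 500000 nM

In a physicochemical assay for solubility (a lower number here means a less soluble compound, a higher number a more soluble compound), compound 1 reads 63000 nM and is the lower of the two measured compounds, while compound 2 reads 500000 nM and lies beyond the scatter above it. Among the compounds with values here, compound 3 `O=C1CC(c2ccc(Cl)c(F)c2)Oc2cc(O)cc(O)c21` keeps the shared core of compound 1 but has fluoro in place of chloro on an aromatic carbon, ortho to a chloro group and meta to a large group fluoro in place of chloro on an aromatic carbon and no measured pair shows this swap alone. Within the data shown here, the only guide is compound 2, which has no chloro group and reads 500000 nM so compound 3 is expected to land between the two measured compounds, nearer the lower one. The expected change is a 2.4-fold higher number from compound 1 to compound 3 (0.38 log units; beyond the scatter) and this upward step should lie only a little beyond the scatter. For compound 3 the estimated value in this assay is 150000 nM with an expected range from 60000 nM to 400000 nM for the measurement.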

Compound 3, solubility: 500000 nM
For compound 3 the middle estimate is 3.3-fold (0.52 log units) below the measured one; the measured number lies above the stated range.
By their numbers in this assay, from the lowest: compound 1; then compounds 2 and 3 (each within the scatter of the next).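

In this assay, putting fluoro in place of chloro on an aromatic carbon, ortho to a chloro group and meta to a large group, gives a 7.9-fold higher number from compound 1 to compound 3 (0.90 log units; beyond the scatter), a step beyond the scatter. Within the data shown here, this is the first pair of compounds that differ in one place only, so this swap can now be read alone, with the remaining chloro group and the rest of the shared core unchanged. Nothing measured here explains the size of this step.

One swap at one position cannot show whether the same change would give a similar step at the chloro group that remains in compound 3. As far as these compounds go, how other groups would read at this position, such as a methoxy group, a nitrile or an amine, also stays open.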